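Swapping a chloro for an ethyl on a weak growth inhibitor

The compounds below may be only part of what the source reports. "The series", "measured", "known", "first", "only" and "open" are said of these compounds alone.

The measure here is a functional assay on HCT-116 cells (Homo sapiens) for inhibition, read by CCK-8 assay, with a stated time of 72 h, tested at 8 uM; a higher number here means more inhibition of growth at the concentration tested, a lower number less inhibition of growth. Compound 1, `Nc1ccccc1NC(=O)/C=C/c1ccc(CSc2ccc(Cl)cc2)cc1`, is the weaker of the two measured compounds: in this assay compound 1 gives 3.27%, the lowest of the two numbers. Among the measured compounds shown here, the only other measured compound, compound 2 with structure `Cc1ccc(SCc2ccc(C(=O)Nc3ccccc3N)cc2)cc1`, gives 84% in this assay, a gap far beyond the usual scatter. For the measured compounds named here, compound 2, however, differs from compound 1 in more than one place, so no single change can be read off from the pair; the two values show only that a closely related compound can reach strong inhibition.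

The unmeasured compound 3, `CCc1ccc(SCc2ccc(/C=C/C(=O)Nc3ccccc3N)cc2)cc1`, differs from compound 1 in one place: ethyl in place of chloro on an aromatic carbon. Going by the values given here, no single-change step among the measured compounds exists to calibrate this swap. Since compound 1 sits at the floor, a drop is hardly possible, and a small rise is expected. The step from compound 1 to compound 3 is estimated at a number 16.7 percentage points higher from compound 1 to compound 3 (beyond the scatter), near the edge of the scatter. Compound 3 is therefore expected to give about 20% in this assay, within a range from 0% to 60%.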

Compound 3, percent growth inhibition at one concentration: 2.68%
For compound 3 the middle estimate is 17.3 percentage points above the measured one; the range from low to high includes it.
By their numbers in this assay, from the lowest: compounds 3 and 1 (each within the scatter of the next); then compound 2.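

Ethyl in place of chloro on this aromatic carbon, para to a large group, gives in this assay a number 0.6 percentage points lower from compound 1 to compound 3 (within the scatter), so the two compounds cannot be told apart in this measure. Among the compounds shown here, this is the only single-place step in the set, and it shows that neither 4-chlorophenyl nor 4-ethylphenyl at this end of the molecule gives more than slight inhibition of growth on the shared core at the concentration tested. Nothing in the data shown explains why the swap makes no measurable difference.

As far as these compounds go, both numbers sit so near the bottom of the scale that a real difference between these two groups could remain hidden, so it stays open whether the same swap would matter on a core that inhibits growth strongly. Also open, from the compounds shown here alone, is whether a different group at this ring position, such as an amine, a carboxylic acid or a longer chain like butyl, would raise the number beyond the usual scatter.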